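The source may report more compounds than this note shows. Statements on the series, on what has been measured and on what is new or still open speak of the compounds shown alone.

In a functional assay on the whole organism for inhibition, with Scenedesmus acutus as the target, with a stated time of 20 h (on this read-out higher numbers stand for weaker inhibition and lower numbers for stronger inhibition), compound 1 (`O=C1C2=C(CCCC2)C(=O)N1c1ccccc1`) gives 10000 nM and compound 2 (`C#CCOc1cc(N2C(=O)C3=C(CCCC3)C2=O)ccc1Cl`) gives 501 nM on the same scale. Compound 2 therefore holds the lower of the two numbers, and its gap to compound 1 lies beyond the usual scatter of repeated measurements. Compound 3 (`CC(C)OC(=O)c1cc(N2C(=O)C3=C(CCCC3)C2=O)ccc1Cl`) has not yet been measured. It carries isopropoxycarbonyl in place of propargyloxy on an aromatic carbon, ortho to a chloro group (isopropoxycarbonyl in place of propargyloxy on an aromatic carbon) and otherwise matches compound 2. Going by the values given here, no measured pair of compounds differs in only one place, so the data do not isolate this exchange and any expectation remains loose. In this assay a small step towards a higher number is expected, perhaps none beyond the scatter, which would leave compound 3 closer to compound 2 at 501 nM than to compound 1. The estimated change is a 1.6-fold higher number from compound 2 to compound 3 (0.20 log units; within the scatter) and would mean slightly weaker inhibition. For compound 3 the expected value is 800 nM within an estimated range of 200 nM to 3000 nM until the measurement is known.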

Compound 3, half-maximal inhibitory concentration: 200 nM
Compound 3: the middle estimate sits 4.0-fold (0.60 log units) above what was measured, and the stated range covers the measured number.
By their numbers in this assay, from the lowest: compound 3; then compound 2; then compound 1.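

In this assay, going by these compounds alone, the exchange of propargyloxy for isopropoxycarbonyl gives a 2.5-fold lower number from compound 2 to compound 3 (0.40 log units; beyond the scatter) and so provides the first comparison of two compounds that differ in one place. It shows that this aromatic carbon, ortho to a chloro group and meta to a large group, accepts a group of 6 heavy atoms in place of one of 4, with stronger inhibition rather than a loss, although the step is modest and rests on this single pair. Nothing measured on these two groups bears on why the number falls.

The compounds shown leave open whether the gain follows from the carbonyl of the ester, from the isopropyl part or simply from the departure of propargyloxy, and a methyl ester or a carboxylic acid at this carbon would begin to separate these readings. They also leave open whether the step would hold without the chloro group, or with a bromo group in its place, and whether an amide or an amine could stand where the ester stands.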